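The source may report more compounds than this note shows. Statements on the series, on what has been measured and on what is new or still open speak of the compounds shown alone.

For the measured compounds named here, compound 1 `COc1ccc(CN(C(=O)CSc2nc3ccccc3[nH]2)c2cc(OC)c(OC)c(OC)c2)cc1` gives 14400 nM in a functional assay on PC-3 cells (Homo sapiens) for antiproliferative activity, read by MTT assay, with a stated time of 48 h (on this read-out higher numbers stand for weaker inhibition and lower numbers for stronger inhibition), the highest of the two numbers measured so far. Compound 2 `COc1ccc(CN(C(=O)CSc2nncs2)c2cc(OC)c(OC)c(OC)c2)cc1` gives 5530 nM in this assay. Going by the values given here, the only measured step, a 2.6-fold lower number from compound 1 to compound 2 (0.42 log units; beyond the scatter), exchanges the group on the sulfur. Compound 3 `COc1ccc(CN(C(=O)CSc2nc3ccccc3o2)c2cc(OC)c(OC)c(OC)c2)cc1` differs from compound 1 by 1,3-benzoxazol-2-yl in place of 1H-benzimidazol-2-yl on a sulfur, again an exchange of the group on that sulfur, though a different group enters. Among the compounds with values here, since the one comparable step was modest, a modest lowering or none beyond the scatter is expected. Compound 3 is therefore estimated at 10000 nM, with a range of 4000 nM to 25000 nM. This corresponds to an expected 1.4-fold lower number from compound 1 to compound 3 (0.16 log units; within the scatter).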

Compound 3, half-maximal inhibitory concentration: 3530 nM
For compound 3 the middle estimate is 2.8-fold (0.45 log units) above the measured one; the whole stated range lies above it.
By their numbers in this assay, from the lowest: compounds 3 and 2 (each within the scatter of the next); then compound 1.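

In this assay, 1,3-benzoxazol-2-yl on the sulfur, with the same heavy-atom count and ring count as 1H-benzimidazol-2-yl, gives a 4.1-fold lower number from compound 1 to compound 3 (0.61 log units; beyond the scatter) and so shows that the lowering on leaving 1H-benzimidazol-2-yl is not confined to 1,3,4-thiadiazol-2-yl. The two replacements stand at a 1.6-fold lower number from compound 2 to compound 3 (0.19 log units; within the scatter) and cannot be ranked against each other here. Nothing available explains these numbers. Going by these compounds, how a 1-methyl-1H-benzimidazol-2-yl group or a plain phenyl on the sulfur would read remains open.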